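Stability When a Methanesulfonamido Group Is Removed

The source may report more compounds than this note shows. Statements on the series, on what has been measured and on what is new or still open speak of the compounds shown alone.

Compound 1 `COc1ccc(-c2c(C)nc3c(N4CC[C@@H](NC(=O)OCc5ccccc5)C4)cc(C)nn23)cc1OC` and compound 2 `COc1ccc(-c2c(C)nc3c(N4CC[C@@H](NS(C)(=O)=O)C4)cc(C)nn23)cc1OC` share one core and differ only on an amine nitrogen, where methylsulfonyl stands in place of benzyloxycarbonyl. In an ADME assay on microsomes from liver (Homo sapiens) for metabolic stability, read by LC-MS, with NADPH named in the record, with a stated time of 60 min, tested at 1 uM, in the absence of a further agent (on this read-out lower numbers stand for a less stable compound and higher numbers for a more stable compound), compound 1 reaches the assay's limit of > 95%, a limit rather than a number. Compound 2 likewise stops at the limit of > 95%. The step that the two limits leave unreadable from compound 1 to compound 2 cannot be read because both values sit at the limit of > 95% in this assay, at which 2 of the 2 values shown sit. Compound 3 `COc1ccc(-c2c(C)nc3c(N4CCCC4)cc(C)nn23)cc1OC` goes one move further and drops the group entirely: hydrogen in place of methanesulfonamido on a saturated ring carbon. No measured step tells how this loss affects the read-out; the only step shown is unreadable, so the expectation rests on compound 2 alone. For compound 3 an estimated step of a number at least 10 percentage points lower from compound 2 to compound 3 (that floor lies within the scatter) in this assay is expected, with a fair chance that the limit is reached again. Compound 3 is therefore expected to show about 85%, somewhere between 60% and 95%.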

Compound 3, percent of the compound remaining: > 95%
Compound 3 gave a limit, no number (the forecaster's own chance of this, stated with the estimate: 50%); middle value at least 10 percentage points away from the limit.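

No step between compound 1, compound 2 and compound 3 can be read in this assay, because all three stop at a limit rather than a number: the limit of > 95% in this assay, at which 3 of the 3 values shown sit.

The compounds shown leave open whether the group on the saturated ring carbon affects stability at all.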